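The source may hold more compounds than are shown below. What is called first, only, known or untested is meant among the compounds shown, and "the series" means these compounds.

Compound 3 `C[C@H]1[C@H](NCc2cccs2)C[C@H]2C[C@@H]1C2(C)C` gives 25000 nM in an ADME assay on MDCK cells (Canis lupus familiaris) for cytotoxicity, read by microscopy, with a stated time of 48 h (a lower number here means that less compound is tolerated, a higher number that more compound is tolerated), level with compound 1 `CCc1csc(CN[C@@H]2C[C@H]3C[C@@H]([C@H]2C)C3(C)C)c1` at 25000 nM, the two together the highest of the three numbers; compound 2 `CCc1ccc(CN[C@@H]2C[C@H]3C[C@@H]([C@H]2C)C3(C)C)s1` sits furthest away at 1560 nM. Compound 4 `Cc1csc(CN[C@@H]2C[C@H]3C[C@@H]([C@H]2C)C3(C)C)c1` differs from compound 3 by methyl in place of hydrogen on an aromatic carbon. The step of no change at the digits printed from compound 1 to compound 3 (within the scatter) concerns an alkyl group on an aromatic carbon of the same ring and showed nothing beyond the scatter, while the step of a 16-fold higher number from compound 2 to compound 3 (1.20 log units; beyond the scatter) concerns another aromatic carbon and bears less directly. A methyl entering where compound 1 carried ethyl is therefore expected to leave the number unchanged, no change at the digits printed from compound 3 to compound 4 (within the scatter). Compound 4 is estimated at 25000 nM, with a range of 12000 nM to 50000 nM.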

Compound 4, minimum cytotoxic concentration: 12500 nM
Estimate against measurement, compound 4: 2.0-fold (0.30 log units) above, and the stated range covers the measured number.
By their numbers in this assay, from the lowest: compound 2; then compounds 4, 1 and 3 (each within the scatter of the next).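

On the aromatic carbon two ring bonds from the ring sulfur and two ring bonds from the ring atom that bears a large group, this assay now has a methyl reading: a 2.0-fold lower number from compound 3 to compound 4 (0.30 log units; within the scatter). Trimming the ethyl of compound 1 to methyl gives a 2.0-fold lower number from compound 1 to compound 4 (0.30 log units; within the scatter), so hydrogen, methyl and ethyl at this position all lie within the scatter of one another. No measured evidence bears on why.

From the compounds shown here alone, a longer chain, an amine or a carboxylic acid at this position remains open. So does whether methyl on the ring carbon bearing the ethyl of compound 2 would track that compound.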